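From compound 2 to compound 3: one exchange

This account rests on a few compounds, and the source may have more. Where it says the series, first, only, none or still open, it means among the compounds named here.

- In a functional assay for inhibition, with Homo sapiens as the target (a lower number here means a stronger inhibitor, a higher number a weaker inhibitor), compound 1 `CCCC(Oc1ccc2c(c1)c(SC(C)(C)C)c(CC(C)(C)C(=O)O)n2Cc1ccc(Cl)cc1)c1ccc2ccccc2n1` gives the limit > 52 nM
- In this assay compound 2 `CC(C)(C)Sc1c(CC(C)(C)C(=O)O)n(Cc2ccc(Cl)cc2)c2ccc(OCc3ccc4cc(F)c(F)cc4n3)cc12` gives 7 nM

Within the data shown here, compound 2 (7 nM) holds the only exact number in this assay so far. Compound 1 stands only as a limit (> 52 nM). Compound 3 `CC(C)(C)Sc1c(CC(C)(C)C(=O)O)n(Cc2ccc(Cl)cc2)c2ccc(OCc3ccc4cnccc4n3)cc12` keeps the shared core and changes one group (a group of 10 heavy atoms (8 carbon, 2 nitrogen; 2 six-membered aromatic rings with 1 hetero atom each) in place of a group of 12 heavy atoms (9 carbon, 1 nitrogen, 2 fluorine; one six-membered aromatic ring of carbon only, one six-membered aromatic ring with 1 hetero atom), on a saturated chain carbon bound to an oxygen on an aromatic ring). Among the measured compounds shown here, no measured step covers this exchange. A weakening beyond the usual scatter is expected, and the estimated step is a 2.9-fold higher number from compound 2 to compound 3 (0.46 log units; beyond the scatter) in this assay with wide uncertainty. In this assay compound 3 is estimated at 20 nM (6 nM to 70 nM).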

Compound 3, half-maximal inhibitory concentration: 3 nM
Compound 3: middle estimate off by 6.7-fold (0.82 log units), on the high side, and the stated range ends above it.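

In this assay, the exchange on the saturated chain carbon bound to an oxygen on an aromatic ring gives a 2.3-fold lower number from compound 2 to compound 3 (0.37 log units; beyond the scatter). The group with 2 six-membered aromatic rings with 1 hetero atom each thus serves at this place without any fluorine, and the number still falls. Nothing measured for these compounds bears on why the number falls. Going by these compounds, the loss of fluorine and the gain of a ring nitrogen arrive together in this one exchange, so their shares stay open. On these data alone, how a methoxy group or an amine on the entering group would read also remains open.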